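One Group Exchanged on an Amine Nitrogen

The source may report more compounds than this note shows. Statements on the series, on what has been measured and on what is new or still open speak of the compounds shown alone.

In a functional assay on HL-60 cells (Homo sapiens) for inhibition, read by CCK-8 assay, with a stated time of 48 h (on this read-out higher numbers stand for weaker inhibition and lower numbers for stronger inhibition), compound 3 `CC(C)c1ccc(Oc2ccc(O)c(O)c2)c(-c2ccsc2S(=O)(=O)NCCNC(=S)Nc2ccc([N+](=O)[O-])cc2)c1` gives 8800 nM, which lies within the scatter of both other measured compounds, compound 1 `O=C(NCCNS(=O)(=O)c1sccc1-c1ccccc1Oc1ccc(O)c(O)c1)Nc1cc(Cl)cc(Cl)c1` and compound 2 `COc1ccc(Oc2ccc(C(C)C)cc2-c2ccsc2S(=O)(=O)NCCNC(=O)Nc2cc(Cl)cc(Cl)c2)cc1OC`. Compound 4 `CC(C)c1ccc(Oc2ccc(O)c(O)c2)c(-c2ccsc2S(=O)(=O)NCCNC(=O)Nc2cc(Cl)cc(Cl)c2)c1` departs from compound 3 on an amine nitrogen: a group of 11 heavy atoms (7 carbon, 1 nitrogen, 1 oxygen, 2 chlorine; one six-membered aromatic ring of carbon only) in place of a group of 12 heavy atoms (7 carbon, 2 nitrogen, 2 oxygen, 1 sulfur; one six-membered aromatic ring of carbon only), on an amine nitrogen. The entering (3,5-dichlorophenyl)carbamoyl is already present in compound 1, at 6900 nM, and in compound 2, at 6500 nM, so no change beyond the scatter is expected in this assay, though any small shift would more likely be towards a lower number. The estimated step is a 1.5-fold lower number from compound 3 to compound 4 (0.18 log units; within the scatter), which is expected to stay within the scatter. For compound 4 the estimate is 5800 nM, with an expected range from 2500 nM to 12000 nM.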

Compound 4, half-maximal inhibitory concentration: 6500 nM
The estimate for compound 4 lay 1.1-fold (0.05 log units) below the measured number; the measured number falls inside the stated range.
By their numbers in this assay, from the lowest: compounds 2, 4, 1 and 3 (each within the scatter of the next).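

In this assay, compound 4 links three single exchanges: (3,5-dichlorophenyl)carbamoyl on the amine nitrogen gives a 1.4-fold lower number from compound 3 to compound 4 (0.13 log units; within the scatter), 3,4-dihydroxyphenyl in place of 3,4-dimethoxyphenyl gives no change at the digits printed from compound 2 to compound 4 (within the scatter), and isopropyl in place of hydrogen gives a 1.1-fold lower number from compound 1 to compound 4 (0.03 log units; within the scatter). All three steps lie within the scatter, so none of these exchanges separates from the others. No other data bear on this result.

On these data alone, whether an acetyl or a plain alkyl chain on that amine nitrogen would move the number beyond the scatter remains open. The same holds for a carboxylic acid in place of the isopropyl.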